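Removing the Benzyl from an Aniline Nitrogen

The source may hold more compounds than are shown below. What is called first, only, known or untested is meant among the compounds shown, and "the series" means these compounds.

Compound 1, `COc1ccc(S(=O)(=O)N2CCc3cccc(NCc4ccccc4)c32)cc1`, gives > 10000 nM in a functional assay on MKN-45 cells (Homo sapiens) for cytotoxicity; on this read-out higher numbers stand for weaker inhibition and lower numbers for stronger inhibition; this is a limit of the assay, not a number.
Compound 2, `COc1ccc(S(=O)(=O)N2CCc3cccc(NC(=O)c4ccco4)c32)cc1`, gives 10.7 nM in this assay.

Compound 1 therefore sits at the limit of > 10000 nM in this assay, at which 1 of the 2 values shown sits, so only a range is known for it. Among the compounds with values here, the one measured step, an at least 930-fold lower number from compound 1 to compound 2 (2.97 log units; beyond the scatter), shows that putting (furan-2-yl)carbonyl in place of benzyl on that nitrogen carries the series from the limit to a strong measured value. Compound 3, `COc1ccc(S(=O)(=O)N2CCc3cccc(N)c32)cc1`, makes a different change at the same place: hydrogen in place of benzyl on a nitrogen on an aromatic ring. Within the data shown here, no measured step covers the loss of the benzyl with nothing entering but a hydrogen, so the step from compound 1 to compound 2 bears on it only by showing how strongly the group on that nitrogen sets the read-out. Because compound 1 sits at the limit of > 10000 nM in this assay, at which 1 of the 2 values shown sits, the expectation for compound 3 is a step that the limit leaves unreadable from compound 1 to compound 3 that stays near the limit, and a limit rather than a number is the likeliest report. Compound 3 is estimated at 15000 nM, within 3000 nM to 80000 nM.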

Compound 3, half-maximal inhibitory concentration: 1200 nM
Compound 3: the middle estimate sits 13-fold (1.10 log units) above what was measured; the measured number lies below the stated range.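

Swapping the benzyl for a bare hydrogen is not a neutral change on this nitrogen: in this assay it gives an at least 8.3-fold lower number from compound 1 to compound 3 (0.92 log units; beyond the scatter), so part of the gain seen earlier goes with the loss of the benzyl, whatever enters in its place. Compound 3 also gives a reference point for the (furan-2-yl)carbonyl group, with a 110-fold higher number from compound 2 to compound 3 (2.05 log units; beyond the scatter), so the larger share of the gain belongs to that group and not merely to the benzyl being gone: among these three compounds, the benzyl goes with the weakest read-out and the (furan-2-yl)carbonyl with the strongest. Only a lower bound on the benzyl step can be given, because compound 1 stands at a limit and not at a number: the limit of > 10000 nM in this assay, at which 1 of the 3 values shown sits.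

The compounds shown leave open whether the gain from compound 3 to the stronger compound needs the furan or only the carbonyl, a question that an acetyl or a benzoyl on the same nitrogen would address. They also leave open whether a methyl there would stay close to compound 3 or fall toward compound 1.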